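Swapping butyl for methylsulfonyl on the shared core

This account rests on a few compounds, and the source may have more. Where it says the series, first, only, none or still open, it means among the compounds named here.

In a functional assay on A549 cells (Homo sapiens) for cytotoxicity (on this read-out higher numbers stand for an effect only at larger amounts of compound and lower numbers for an effect already at smaller amounts), three compounds with the same core have been tested. Compound 1 (`CCOc1cc(-c2ccccc2)nc2ccccc12`) gives > 10 ug/mL as a limit and not as a number. Compound 2 (`CC(C)Oc1cc(-c2ccccc2)nc2ccccc12`) gives > 10 ug/mL as a limit too. Compound 3 (`CCCCOc1cc(-c2ccccc2)nc2ccccc12`) also gives > 10 ug/mL as a limit. Compound 3 therefore stands with the other two, and the whole set reads as follows: the limit of > 10 ug/mL in this assay, at which 3 of the 3 values shown sit.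

The next structure is compound 4 (`CS(=O)(=O)Oc1cc(-c2ccccc2)nc2ccccc12`), which differs from compound 3 in one place: methylsulfonyl in place of butyl on an oxygen on an aromatic ring. Unlike butyl, methylsulfonyl carries hydrogen-bond acceptors.

For the measured compounds named here, three measured steps bear on this change, namely a step that the two limits leave unreadable from compound 1 to compound 2 and a step that the two limits leave unreadable from compound 1 to compound 3 and also a step that the two limits leave unreadable from compound 2 to compound 3 among the chains on that oxygen. None of them has a readable size, and none brings in methylsulfonyl, so they offer no size or direction to carry over. No step beyond the scatter can be predicted with confidence in this assay and another limit is the likeliest result. This expectation rests on compound 3 with its limit of > 10 ug/mL as the only anchor. The estimated step is a step that the limit leaves unreadable from compound 3 to compound 4 with no direction firmly expected. For compound 4 the estimated value is 15 ug/mL within an expected range of 6 ug/mL to 40 ug/mL for a measured number.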

Compound 4, half-maximal effective concentration: 6.21 ug/mL
The estimate for compound 4 lay 2.4-fold (0.38 log units) above the measured number; measured number inside the range.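

Compound 4 is the only compound shown that gives a measured number and not a limit in this assay, so methylsulfonyl on this oxygen is the one change here that can be placed on the scale at all: the limit of > 10 ug/mL in this assay, at which 3 of the 4 values shown sit. Set against the three chains, the change gives an at least 1.6-fold lower number from compound 3 to compound 4 (0.20 log units; that floor lies within the scatter), then an at least 1.6-fold lower number from compound 2 to compound 4 (0.20 log units; that floor lies within the scatter), and also an at least 1.6-fold lower number from compound 1 to compound 4 (0.20 log units; that floor lies within the scatter). Each of these is only a floor, set by a limit on one side, so the true gap could be larger, but the floor alone stays within the usual scatter and does not by itself establish a real difference.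

The compounds shown leave open whether the sulfonyl part matters or whether other groups on this oxygen that are not simple chains, such as an acetyl group or a benzenesulfonyl group, would also give a measured number in this assay. They also leave open whether a longer chain on the sulfur, as in butylsulfonyl, would move that number in either direction.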